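Five-membered to six-membered aryl swap: clearance notes

The source may report more compounds than this note shows. Statements on the series, on what has been measured and on what is new or still open speak of the compounds shown alone.

Compound 3 `Nc1ccc(S(=O)(=O)N2CCN(c3ncc(C(O)(C(F)(F)F)C(F)(F)F)cc3-c3ccoc3)CC2)cn1` gives only a limit in an ADME assay (liver) for metabolic stability, with Liver microsome (Homo sapiens) as the target, using microsomes and NADPH, with a stated time of 30 min, tested at 1 uM (on this read-out lower numbers stand for slow clearance and higher numbers for fast clearance), reported as < 14 mL.min-1.g-1, which is a limit of the assay and not a number. Its neighbours on the numbers are compound 1 `COCC#Cc1cc(C(O)(C(F)(F)F)C(F)(F)F)cnc1N1CCN(S(=O)(=O)c2ccc(N)nc2)CC1`, which in this assay gives 15 mL.min-1.g-1, and compound 2 `Cn1cc(-c2cc(C(O)(C(F)(F)F)C(F)(F)F)cnc2N2CCN(S(=O)(=O)c3ccc(N)nc3)CC2)cn1`, which in this assay gives 19 mL.min-1.g-1. The three steps among them are all small: a 1.3-fold higher number from compound 1 to compound 2 (0.10 log units; within the scatter), an at least 1.0-fold lower number from compound 1 to compound 3 (0.02 log units; that floor lies within the scatter) and an at least 1.3-fold lower number from compound 2 to compound 3 (0.13 log units; that floor lies within the scatter). None moves beyond the scatter, so replacements of the group on this aromatic carbon have kept clearance low, with the limit of < 14 mL.min-1.g-1 in this assay, at which 1 of the 3 values shown sits.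

Compound 4 `Nc1ccc(S(=O)(=O)N2CCN(c3ncc(C(O)(C(F)(F)F)C(F)(F)F)cc3-c3cncc(F)c3)CC2)cn1` differs from compound 3 as 5-fluoropyridin-3-yl in place of furan-3-yl on an aromatic carbon. Every earlier replacement at this carbon gave a step within the scatter, so no movement beyond the scatter is expected in this assay for this one either. Compound 4 is therefore estimated at 14 mL.min-1.g-1, within a range of 7 mL.min-1.g-1 to 28 mL.min-1.g-1. The expected step for compound 4 is a number no lower from compound 3 to compound 4 (the limit leaves the size open), and a limit rather than a number may again be reported.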

Compound 4, intrinsic clearance in microsomes: 24 mL.min-1.g-1
Estimate against measurement, compound 4: 1.7-fold (0.23 log units) below; low and high end bracket the measured number.
By their numbers in this assay, from the lowest: compounds 1, 2 and 4 (each within the scatter of the next). At a limit, below all of these: compound 3.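

The only six-membered aromatic ring shown at this carbon, 5-fluoropyridin-3-yl, leaves clearance in this assay within the scatter of the two measured neighbours: a 1.3-fold higher number from compound 2 to compound 4 (0.10 log units; within the scatter) and a 1.6-fold higher number from compound 1 to compound 4 (0.20 log units; within the scatter). Against the five-membered furan-3-yl, only a floor can be read, since compound 3 gives a limit and not a number: an at least 1.7-fold higher number from compound 3 to compound 4 (0.23 log units; that floor lies within the scatter). Compound 3 therefore remains the one compound here without a number: the limit of < 14 mL.min-1.g-1 in this assay, at which 1 of the 4 values shown sits.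

From the compounds shown here alone, the size of the step from furan-3-yl to 5-fluoropyridin-3-yl stays open, and these compounds do not separate the change in ring size from the added fluorine. Going by these compounds, a plain pyridin-3-yl would address that second point, while an amine or a carboxylic acid on this carbon remains untested territory for the series.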